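The source may report more compounds than this note shows. Statements on the series, on what has been measured and on what is new or still open speak of the compounds shown alone.

Compound 1 `O=Cc1coc(C(=O)CCCCCCc2ccccc2)n1` and compound 2 `CNC(=O)c1coc(C(=O)CCCCCCc2ccccc2)n1` share a core in which a five-membered aromatic ring carrying nitrogen and oxygen is joined to a ketone and a long chain ending in a benzene ring. In an assay on HEK-293T cells for inhibition of diacylglycerol lipase-alpha (Homo sapiens), read by colorimetric assay (a higher number here means a weaker inhibitor, a lower number a stronger inhibitor), compound 1 gives 1510 nM. For compound 2 this assay reports only a limit, > 10000 nM, so its true number is not known. Among the compounds with values here, the one step that was measured, an at least 6.6-fold higher number from compound 1 to compound 2 (0.82 log units; beyond the scatter), therefore shows a clear loss of potency, and because the value of compound 2 sits at the limit of > 10000 nM in this assay, at which 1 of the 2 values shown sits, the loss may be larger than the step states.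

Compound 3 `O=C(CCCCCCc1ccccc1)c1nc(-c2ccccc2)co1` differs from compound 2 in one place: phenyl in place of methylcarbamoyl on an aromatic carbon. Within the data shown here, no measured step swaps a group of this kind, so the step from the aldehyde to the methylamide is the only guide, and it concerns a different pair of groups. Compound 3 is expected to give 3000 nM, within a broad range of 300 nM to 30000 nM, so that the estimated step is an at least 3.3-fold lower number from compound 2 to compound 3 (0.52 log units; beyond the scatter) and it remains uncertain whether a number rather than a limit will be obtained.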

Compound 3, half-maximal inhibitory concentration: 8710 nM
Beside the measured number, compound 3's estimate is 2.9-fold (0.46 log units) below it; the measured number falls inside the stated range.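

Phenyl in place of methylcarbamoyl on this aromatic carbon gives an at least 1.1-fold lower number from compound 2 to compound 3 (0.05 log units; that floor lies within the scatter), so it cannot be said that compound 3 is a stronger inhibitor than compound 2, because compound 2 has only a limit and not a number: the limit of > 10000 nM in this assay, at which 1 of the 3 values shown sits.

Phenyl in place of formyl gives a 5.8-fold higher number from compound 1 to compound 3 (0.76 log units; beyond the scatter), a step that is beyond the scatter, so a large ring of carbon only at this place does not match the small formyl group. Across these three compounds, both replacements of the formyl group of compound 1, the methylcarbamoyl of compound 2 and the phenyl of compound 3, give a weaker inhibitor in this assay, and neither compound goes against this.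

The compounds shown leave open whether a carboxylic acid, a methyl ester or a simple amine on this aromatic carbon would match or beat the formyl group of compound 1. Also open, on these data alone, is whether a chlorine on the phenyl, or a shorter chain in place of the one ending in a benzene ring, would change these steps.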